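The source may hold more compounds than are shown below. What is called first, only, known or untested is meant among the compounds shown, and "the series" means these compounds.

Working notes on the series. In an assay on COS-7 cells for inhibition of patatin-like phospholipase domain-containing protein 2 (Mus musculus) (a lower number here means a stronger inhibitor, a higher number a weaker inhibitor), compound 1 `CCOC(=O)c1cccc(-c2ccsc2)c1` gives 75000 nM and compound 2 `CCOC(=O)c1cccc(-c2ccc3[nH]ccc3c2)c1` gives 60000 nM. Compound 3 `CCNS(=O)(=O)c1cccc(-c2ccc(OCC)cc2)c1` gives 200000 nM in this assay, the highest of the three numbers, with compounds 1 and 2 both lower by more than the scatter. Compound 4 `CCOc1ccc(-c2cccc(C(=O)N3CCCC3)c2)cc1` has not been measured. It differs from compound 3 in one place: (pyrrolidin-1-yl)carbonyl in place of ethylsulfamoyl on an aromatic carbon. Among the compounds with values here, no step between measured compounds covers this change, so there is no direct precedent for it. The expectation for this assay is a moderate fall in the number from compound 3 to compound 4, with compound 4 estimated at 80000 nM, within 30000 nM to 250000 nM. That estimate means a step of a 2.5-fold lower number from compound 3 to compound 4 (0.40 log units; beyond the scatter).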

Compound 4, half-maximal inhibitory concentration: 160000 nM
For compound 4 the middle estimate is 2.0-fold (0.30 log units) below the measured one; low and high end bracket the measured number.
By their numbers in this assay, from the lowest: compounds 2 and 1 (each within the scatter of the next); then compounds 4 and 3 (each within the scatter of the next).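

In this assay the change to (pyrrolidin-1-yl)carbonyl in place of ethylsulfamoyl on this aromatic carbon gives a 1.3-fold lower number from compound 3 to compound 4 (0.10 log units; within the scatter) and so shows no readable difference for this pair. Losing the hydrogen-bond donor and gaining a five-membered non-aromatic ring therefore leave the number unmoved here, though this rests on a single step. No available evidence explains this result.

From the compounds shown here alone, whether a carboxylic acid, a primary amide or an ethyl ester at this position on the core of compound 3 would move the number remains open.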